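Reading cell toxicity across one small compound set

This account rests on a few compounds, and the source may have more. Where it says the series, first, only, none or still open, it means among the compounds named here.

Values so far in an ADME assay on THP-1 cells (Homo sapiens) for cytotoxicity, read by flow cytometry and propidium iodide staining, with a stated time of 72 h; on this read-out lower numbers stand for stronger inhibition and higher numbers for weaker inhibition
Compound 1 `CC(=O)Nc1ccc(O)c(C(=O)/C=C/c2ccccc2)c1` gives 85500 nM
Compound 2 `CC(=O)Nc1ccc2oc(-c3cccc(C(F)(F)F)c3)cc(=O)c2c1` gives 50000 nM
Compound 3 `COc1ccccc1-c1oc2ccc(NC(C)=O)cc2c(=O)c1O` gives > 125000 nM as a limit

Compound 3 stands at > 125000 nM, which is a limit of the assay and not a number. Going by these compounds, it therefore marks the end of the measurable range here, and its true value is unknown.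

Compound 4 `CC(=O)Nc1ccc2oc(-c3cccc(F)c3)c(O)c(=O)c2c1` keeps the core of compound 3 and carries 3-fluorophenyl in place of 2-methoxyphenyl on an aromatic carbon, next to the ring oxygen and ortho to a hydroxy group. The counted difference is 3-fluorophenyl in place of 2-methoxyphenyl on an aromatic carbon and nothing else changes.

Among the compounds with values here, no pair of measured compounds differs in one place only, so no measured step speaks directly to this change. Within the data shown here, the only numbers available come from compound 1 at 85500 nM and compound 2 at 50000 nM, and these two lie within the usual scatter of each other. Compound 4 is expected to land in that region, which would be a move toward lower numbers in this assay and so toward stronger inhibition. The estimated change is an at least 1.6-fold lower number from compound 3 to compound 4 (0.22 log units; that floor lies within the scatter) and remains loose, as one end of it rests on a limit. For compound 4 the estimated value is 75000 nM, with an expected range from 35000 nM to 125000 nM and a real chance that only a limit is reported.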

Compound 4, half-maximal inhibitory concentration: 36000 nM
Compound 4: middle estimate off by 2.1-fold (0.32 log units), on the high side, within the range that was stated.
By their numbers in this assay, from the lowest: compounds 4, 2 and 1 (each within the scatter of the next, the first and the last beyond it). At a limit, above all of these: compound 3.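

In this assay, within the data shown here, putting 3-fluorophenyl in place of 2-methoxyphenyl on the aromatic carbon next to the ring oxygen gives an at least 3.4-fold lower number from compound 3 to compound 4 (0.54 log units; beyond the scatter), the first step in this set that can be read at all. This shows that the group at this position matters on this core: changing that one group brings the compound from the end of the measurable range to a real number, and a lower number here means more toxicity to the cells. Compound 3 remains a limit and not a number, so the step gives only a floor and its full size stays unknown: the limit of > 125000 nM in this assay, at which 1 of the 4 values shown sits.

With only these two groups compared at this position, the compounds shown cannot tell whether the change belongs to the arrival of the fluorine, the loss of the methoxy group, or where each sits on the phenyl ring. They also leave open how a plain phenyl, an amine or a carboxylic acid at this position would read, and whether the same swap would have a similar effect without the hydroxy group on the neighbouring carbon.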